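Compound 3: a step away from a limit

This account rests on a few compounds, and the source may have more. Where it says the series, first, only, none or still open, it means among the compounds named here.

Measured in an ADME assay on Caco-2 cells (Homo sapiens) for permeability; a lower number here means that the compound crosses the layer more slowly, a higher number that the compound crosses the layer faster:
- Compound 1 `CCCS(=O)(=O)N1CCC(CNC(=O)c2ccc(F)cc2C(F)(F)F)(C(=O)N2CCOCC2)CC1` gives > 22 10^-6 cm/s, a limit and not a number.
- Compound 2 `CCCS(=O)(=O)N1CCC(CNC(=O)c2c(F)ccc(Cl)c2F)(C(=O)N2CCOCC2)CC1` gives > 22 10^-6 cm/s, a limit and not a number.

Compound 2 stands at > 22 10^-6 cm/s, which is a limit of the assay rather than an exact reading. It shares this position with compound 1, as the limit of > 22 10^-6 cm/s in this assay, at which 2 of the 2 values shown sit, shows.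

The next compound is compound 3 `CCCS(=O)(=O)N1CCC(CNC(=O)c2ccccc2Cl)(C(=O)N2CCOCC2)CC1`. The change is 2-chlorophenyl in place of 3-chloro-2,6-difluorophenyl on a carbonyl carbon.

Among the measured compounds shown here, only one measured step bears on this change, since it also alters the group on that carbonyl carbon. That step is a step that the two limits leave unreadable from compound 1 to compound 2, so it offers no size to carry over. The data therefore point to no direction, and no step beyond the usual scatter is expected in this assay. The expected step is a step that the limit leaves unreadable from compound 2 to compound 3.

The estimated value for compound 3 is 26 10^-6 cm/s. The expected range runs from 14 10^-6 cm/s to 45 10^-6 cm/s, and the result may again be reported only as a limit.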

Compound 3, apparent permeability: > 22 10^-6 cm/s
Compound 3: no number, only a limit; the forecaster's own chance of this, stated with the estimate: 65%; the middle value is on the limit's open side.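

In this assay compound 3 gives > 22 10^-6 cm/s, a limit and not a number. Its steps from compound 1 and compound 2 cannot be read, since all three compounds sit at the same limit: the limit of > 22 10^-6 cm/s in this assay, at which 3 of the 3 values shown sit. The compounds shown leave open how far apart their true permeabilities lie, and whether changing the group on the carbonyl carbon matters at all.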